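The source may hold more compounds than are shown below. What is called first, only, known or untested is meant among the compounds shown, and "the series" means these compounds.

Three compounds have been measured in a functional assay on SK-OV-3 cells (Homo sapiens) for cytotoxicity; on this read-out higher numbers stand for weaker inhibition and lower numbers for stronger inhibition:

Compound 1 `O=C(CCCCCCc1nc2ccc(F)cc2[nH]1)NO`: 1900 nM
Compound 2 `Cn1c(CCCCCCC(=O)NO)nc2ccccc21`: 3000 nM
Compound 3 `O=C(CCCCCCc1nc2ccccc2n1C1CC1)NO`: 9500 nM

All three share the same core, a hydroxamic acid on a six-carbon chain attached to a fused two-ring system, and differ only in what sits on the ring nitrogen. On these numbers compound 3 stands highest, meaning it is the weakest inhibitor of the three; compound 2 gives a lower number, and compound 1, which carries no group on that nitrogen but a fluorine on the ring, gives the lowest number shown.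

Compound 4 `O=C(CCCCCCc1nc2ccccc2n1-c1ccccc1)NO` differs from compound 3 in one place: phenyl in place of cyclopropyl on an aromatic nitrogen. Within the data shown here, only one measured step bears on this change, and it also enlarged the group on the same nitrogen: a 3.2-fold higher number from compound 2 to compound 3 (0.50 log units; beyond the scatter). That step weakened inhibition, which suggests that enlarging the group further may weaken it again, although a single step is a thin basis and the new group is of a different kind.

Compound 4 is therefore expected to give a somewhat higher number than its neighbour, a 1.3-fold higher number from compound 3 to compound 4 (0.10 log units; within the scatter), with wide uncertainty. The estimate for compound 4 is 12000 nM, within a range from 4000 nM to 40000 nM.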

Compound 4, half-maximal inhibitory concentration: > 20000 nM
Compound 4 gave a limit, no number (the forecaster's own chance of this, stated with the estimate: 15%); at least 1.6-fold (0.22 log units) between middle value and limit.
By their numbers in this assay, from the lowest: compounds 1 and 2 (each within the scatter of the next); then compound 3. At a limit, above all of these: compound 4.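

In this assay compound 4 reaches a limit of the assay and gives no number: the limit of > 20000 nM in this assay, at which 1 of the 4 values shown sits. Phenyl in place of cyclopropyl on this aromatic nitrogen still weakens inhibition, an at least 2.1-fold higher number from compound 3 to compound 4 (0.32 log units; beyond the scatter), so the rise already seen with a 3.2-fold higher number from compound 2 to compound 3 (0.50 log units; beyond the scatter) does not level off at the cyclopropyl group. Measured against methyl, phenyl gives an at least 6.6-fold higher number from compound 2 to compound 4 (0.82 log units; beyond the scatter), so the number rises with each replacement across these three groups on this nitrogen, while compound 1, which differs from them in more than one place, cannot be placed in this line.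

On these data alone, what remains open is whether any other group on this nitrogen behaves like phenyl or reverses the trend, such as a benzyl group, a pyridine ring or a short chain ending in an amine. Also unknown is how far the true value of compound 4 lies beyond its limit, so the full size of both steps that end at compound 4 cannot be read from these data.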